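Vinyl ketone amides: benzothiazole to hydroxyethyl on the nitrogen

A few compounds are considered here, and "the series" means these few. Any claim that something is new, unique, unknown or untested is made for them only; others in the source may bear on it.

Measured so far in a functional assay on CLL cells (Homo sapiens) for cytotoxicity, read by MTT assay, with a stated time of 48 h; on this read-out higher numbers stand for an effect only at larger amounts of compound and lower numbers for an effect already at smaller amounts:
compound 1 `C=C(CC)C(=O)c1ccc(OCC(=O)Nc2nc3ccccc3s2)c(Cl)c1Cl` gives 1500 nM
compound 3 `C=C(CC)C(=O)c1ccc(OCC(=O)Nc2ccc(/C=C/C(=O)O)cc2)c(Cl)c1Cl` gives 3000 nM
compound 2 `C=C(CC)C(=O)c1ccc(OCC(=O)Nc2ccc(S(=O)(=O)O)cc2)c(Cl)c1Cl` gives only a limit, > 25000 nM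

Compound 1 holds the lowest of the two numbers; compound 3 stands within the scatter of it, so no order between these two can be read. Compound 2 sits at the limit of > 25000 nM in this assay, at which 1 of the 3 values shown sits, and contributes no number. Among the compounds with values here, the single measured step, an at least 8.3-fold lower number from compound 2 to compound 3 (0.92 log units; beyond the scatter), concerns the substituent on the aromatic ring of the amide part and leaves the amide nitrogen untouched, so it bears only loosely on the step now followed.

Compound 4 `C=C(CC)C(=O)c1ccc(OCC(=O)NCCO)c(Cl)c1Cl` differs from compound 1 as follows: 2-hydroxyethyl in place of 1,3-benzothiazol-2-yl on an amide-type nitrogen. Within the data shown here, no measured pair changes the group on the amide nitrogen itself, so the expectation rests on compound 1 alone, with the observation that both numbered compounds carry an aromatic group at this position while compound 4 carries none. A higher number in this assay than for compound 1 is expected, a step of a 4.0-fold higher number from compound 1 to compound 4 (0.60 log units; beyond the scatter), with a real chance that only a limit is returned. Compound 4 is therefore estimated at 6000 nM, between 1500 nM and 25000 nM.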

Compound 4, half-maximal effective concentration: > 25000 nM
Compound 4: only a limit was reported (the forecaster's own chance of this, stated with the estimate: 30%); middle value at least 4.1-fold (0.61 log units) away from the limit.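

In this assay, within the data shown here, 2-hydroxyethyl in place of 1,3-benzothiazol-2-yl on the amide-type nitrogen gives an at least 16-fold higher number from compound 1 to compound 4 (1.22 log units; beyond the scatter), the only measured change at this nitrogen and a large one. Compound 4 gives > 25000 nM, which is a limit and not a number. Compound 4 and compound 2 cannot be ordered against each other: the limit of > 25000 nM in this assay, at which 2 of the 4 values shown sit.

The compounds shown do not separate the loss of the 1,3-benzothiazol-2-yl rings from the entry of the hydroxyl of the 2-hydroxyethyl group. An unsubstituted phenyl group or a plain ethyl chain on this nitrogen would tell these two apart, and a longer chain ending in hydroxyl would show whether chain length matters here.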